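Dropping a chloro group from a dichlorinated purine core

The source may report more compounds than this note shows. Statements on the series, on what has been measured and on what is new or still open speak of the compounds shown alone.

- compound 1 `ClCc1cccc(Cn2cnc3ncnc(Cl)c32)c1`: 1730 nM
- compound 2 `ClCc1ccc(Cn2cnc3nc(Cl)nc(Cl)c32)cc1`: 1620 nM
- compound 3 `ClCc1cccc(Cn2cnc3nc(Cl)nc(Cl)c32)c1`: 460 nM

In a functional assay on MDA-MB-231 cells (Homo sapiens) for cytotoxicity, read by sulforhodamine B assay, with a stated time of 48 h (on this read-out lower numbers stand for stronger inhibition of growth and higher numbers for weaker inhibition of growth), compound 3 gives 460 nM, the lowest number of the three measured compounds. Compound 1 is obtained from compound 3 by a single change, (hydrogen in place of chloro on an aromatic carbon), and the result is a 3.8-fold higher number from compound 3 to compound 1 (0.58 log units; beyond the scatter). Compound 2 carries the same atoms as compound 3, joined differently; the difference between the two cores is not broken down here. In this assay compound 2 gives 1620 nM, within the scatter of compound 1.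

Compound 4 `ClCc1ccc(Cn2cnc3ncnc(Cl)c32)cc1` has not been measured. It is related to compound 2 by the same change, (hydrogen in place of chloro on an aromatic carbon). If that change behaves as it did from compound 3 to compound 1, the number for compound 4 is expected to rise from that of compound 2 by a 3.7-fold higher number from compound 2 to compound 4 (0.57 log units; beyond the scatter), because the earlier step was a 3.8-fold higher number from compound 3 to compound 1 (0.58 log units; beyond the scatter). Among the measured compounds shown here, with only one example of this change to rest on, the uncertainty is wide. Compound 4 is therefore estimated at 6000 nM, most likely between 2500 nM and 15000 nM.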

Compound 4, concentration for 50% growth inhibition: 1770 nM
Beside the measured number, compound 4's estimate is 3.4-fold (0.53 log units) above it, and the stated range ends above it.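

In this assay, putting hydrogen in place of chloro on the aromatic carbon between two ring nitrogen atoms gives a 1.1-fold higher number from compound 2 to compound 4 (0.04 log units; within the scatter) and so leaves the number for this core within the usual scatter. The same change therefore does not carry over with the same size from one core to the other: the same change on two cores in this assay, a 3.8-fold higher number (0.58 log units; beyond the scatter) from compound 3 to compound 1 and a 1.1-fold higher number (0.04 log units; within the scatter) from compound 2 to compound 4, 3.4-fold (0.54 log units) apart, beyond the scatter of two such steps. A step seen on one core in this series cannot simply be added to another, but two pairs do not show what sets the cores apart or how the change would behave on any further core.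

The compounds shown leave open whether a different group on that same aromatic carbon, such as an amine or a methoxy group, would also give steps that differ between the two cores. They also leave open how these steps would look if the chloromethyl group gave way to a hydroxymethyl group or a longer chain.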